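This account rests on a few compounds, and the source may have more. Where it says the series, first, only, none or still open, it means among the compounds named here.

Compound 1 `N#CC1=C(N)Oc2c(c3nc4ccccc4nc3c3ccccc23)C12C(=O)N(Cc1cnnn1-c1ccccc1Cl)c1ccccc12` gives in an ADME assay on L02 cells (Homo sapiens) for antiproliferative activity, read by MTT assay, with a stated time of 48 h (a lower number here means a stronger inhibitor, a higher number a weaker inhibitor), only a limit of the assay, > 50000 nM.
Compound 2 `CCc1ccccc1-n1nncc1CN1C(=O)C2(C(C#N)=C(N)Oc3c(N)cc4nc5ccccc5nc4c32)c2ccccc21` gives in this assay 22900 nM.
Compound 3 `CCOc1ccc(-n2nncc2CN2C(=O)C3(C(C#N)=C(N)Oc4c(N)cc5nc6ccccc6nc5c43)c3ccccc32)cc1` gives in this assay only a limit of the assay, > 50000 nM.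

Compound 3 thus stands at the limit, where two of the three values shown sit (the limit of > 50000 nM in this assay, at which 2 of the 3 values shown sit). Compound 4 `N#CC1=C(N)Oc2c(N)cc3nc4ccccc4nc3c2C12C(=O)N(Cc1cnnn1-c1cc(Cl)ccc1Cl)c1ccccc12` differs from compound 3 by 2,5-dichlorophenyl in place of 4-ethoxyphenyl on an aromatic nitrogen. Among the measured compounds shown here, the only measured step at this aromatic nitrogen is an at least 2.1-fold higher number from compound 2 to compound 3 (0.33 log units; beyond the scatter), which runs toward the limit, and compound 1 also sits at that limit. The account therefore expects no step beyond the scatter for an at least 1.1-fold lower number from compound 3 to compound 4 (0.04 log units; that floor lies within the scatter), with compound 4 most likely reported again only as a limit. Compound 4 is estimated at 45000 nM, ranging from 18000 nM to 120000 nM.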

Compound 4, half-maximal inhibitory concentration: > 50000 nM
Compound 4 was reported as a limit; the forecaster's own chance of this, stated with the estimate: 65%; middle value at least 1.1-fold (0.04 log units) away from the limit.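

Among the compounds shown here, at this aromatic nitrogen in this assay, 2,5-dichlorophenyl in place of 2-ethylphenyl gives an at least 2.1-fold higher number from compound 2 to compound 4 (0.33 log units; beyond the scatter), so 4-ethoxyphenyl is no longer the only group with a step of this direction away from compound 2. The step between compound 3 and compound 4 cannot be read, as both values are limits. The limit now holds most of the compounds shown: the limit of > 50000 nM in this assay, at which 3 of the 4 values shown sit.

For the compounds shown here, compound 2 remains the only compound here with a measured number. From the compounds shown here alone, it stays open whether an amine or a carboxylic acid on this phenyl ring would also give a number rather than a limit.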